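Methoxy addition on two cores, cytotoxicity working notes

The compounds below may be only part of what the source reports. "The series", "measured", "known", "first", "only" and "open" are said of these compounds alone.

Compound 1 `COc1ccc(/C=N/n2c(C)nc3c(cnn3-c3ccc(Cl)cc3)c2=O)cc1OC` and compound 2 `COc1cc(/C=N/n2c(C)nc3c(cnn3-c3ccc(Cl)cc3)c2=O)cc(OC)c1OC` share one core; compound 3 `COc1ccc(/C=N/NC(=O)c2cn[nH]c2NC(C)=O)cc1` and compound 4 `COc1ccc(/C=N/NC(=O)c2cn[nH]c2NC(C)=O)cc1OC` share another, and the difference between the two cores is not broken down here. In a functional assay on MCF7 cells (Homo sapiens) for cytotoxicity, read by colorimetric assay and sulforhodamine B assay, with a stated time of 48 h (on this read-out higher numbers stand for weaker inhibition and lower numbers for stronger inhibition), compound 1 gives 25000 nM and compound 2 gives 7600 nM, the change methoxy in place of hydrogen on an aromatic carbon giving a 3.3-fold lower number from compound 1 to compound 2 (0.52 log units; beyond the scatter). In this assay compound 3 gives 61700 nM, the highest of the three numbers. Compound 4 carries the same kind of change, (methoxy in place of hydrogen on an aromatic carbon), though here the place is not also meta to a methoxy group, and the core is different. The matched step a 3.3-fold lower number from compound 1 to compound 2 (0.52 log units; beyond the scatter) lowered the number on the other core. On the present core a smaller lowering is expected for compound 4, a 2.2-fold lower number from compound 3 to compound 4 (0.34 log units; beyond the scatter). Compound 4 is thus estimated at 28000 nM in this assay, with a range from 9000 nM to 75000 nM.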

Compound 4, half-maximal inhibitory concentration: 37100 nM
Beside the measured number, compound 4's estimate is 1.3-fold (0.12 log units) below it; the range from low to high includes it.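

On the core of compound 3, methoxy in place of hydrogen on an aromatic carbon gives a 1.7-fold lower number from compound 3 to compound 4 (0.22 log units; within the scatter) in this assay, so on this core the step cannot be told apart from no change. Set against the step on the other core, it does not differ beyond what repeated measurements allow: the same change on two cores in this assay, a 3.3-fold lower number (0.52 log units; beyond the scatter) from compound 1 to compound 2 and a 1.7-fold lower number (0.22 log units; within the scatter) from compound 3 to compound 4, 2.0-fold (0.30 log units) apart, within the scatter of two such steps. This is compatible with the change carrying across the two cores, but it does not establish this, as each core offers a single pair and the surroundings of the added methoxy differ between the pairs.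

The compounds shown leave open whether a hydroxyl, an amine or a longer chain such as ethoxy on that aromatic carbon would behave as methoxy does on either core.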